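The source may report more compounds than this note shows. Statements on the series, on what has been measured and on what is new or still open speak of the compounds shown alone.

Of the compounds shown here, three with closely related structures have been tested in a functional assay on ECa-109 cells (Homo sapiens) for cytotoxicity, read by MTT assay, with a stated time of 48 h; on this read-out lower numbers stand for stronger inhibition and higher numbers for weaker inhibition. Compound 1 `COc1ccc(-c2c[nH]c(=O)n2-c2cc(OC)c(OC)c(OC)c2)cc1[N+](=O)[O-]` reads > 50000 nM, which is a limit of the assay and not a number. Compound 2 `COc1ccc(-c2cn(C(=O)Nc3cc(OC)c(OC)c(OC)c3)c(=O)n2-c2cc(OC)c(OC)c(OC)c2)cc1O` reads > 50000 nM, which is also a limit. Within the data shown here, compound 3 `COc1cc(-n2c(-c3ccc(Br)cc3)cn(C(C)=O)c2=O)cc(OC)c1OC` gives 3800 nM, the only true number so far.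

Compound 4 `COc1ccc(-c2cn(C(C)=O)c(=O)n2-c2cc(OC)c(OC)c(OC)c2)cc1OC` keeps the acetyl group of compound 3 but has 3,4-dimethoxyphenyl in place of 4-bromophenyl on an aromatic carbon. Among the measured compounds shown here, no measured pair isolates this change, so its size has to be judged loosely. Compound 1 and compound 2 also carry oxygen groups on that aromatic ring and lie at the limit of > 50000 nM in this assay, at which 2 of the 3 values shown sit, although they differ from compound 3 elsewhere too, and this tilts the expectation towards weaker inhibition. In this assay a moderate weakening is therefore expected, an estimated 2.1-fold higher number from compound 3 to compound 4 (0.32 log units; beyond the scatter). For compound 4 the estimated value is 8000 nM, with an expected range of 1500 nM to 40000 nM.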

Compound 4, half-maximal inhibitory concentration: > 50000 nM
Compound 4 ended at the assay's limit; the forecaster's own chance of this, stated with the estimate: 20%; middle value at least 6.2-fold (0.79 log units) away from the limit.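

With the acetyl group kept, placing 3,4-dimethoxyphenyl in place of 4-bromophenyl on this aromatic carbon gives, in this assay, an at least 13-fold higher number from compound 3 to compound 4 (1.11 log units; beyond the scatter), so this single change is enough to take the measurable inhibition away. Going by these compounds, compound 4 reads > 50000 nM, which is a limit of the assay and not a number, so the true size of the step stays unknown. Compound 3 thus remains the only compound here with a true number: the limit of > 50000 nM in this assay, at which 3 of the 4 values shown sit.

Still open, on these data alone, is whether the step follows from losing the bromine or from gaining the two methoxy groups, which a plain phenyl or a 4-methoxyphenyl at this position would help to separate. Also open, as far as these compounds go, is whether a 4-chlorophenyl here, or a longer acyl chain in place of the acetyl group, would keep or strengthen the inhibition seen with compound 3.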